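Adding a Third Methoxy Group to Compound 3

The compounds below may be only part of what the source reports. "The series", "measured", "known", "first", "only" and "open" are said of these compounds alone.

Of the compounds shown here, three sharing one core have been measured in a functional assay on MCF7 cells (Homo sapiens) for cytotoxicity, read by sulforhodamine B assay, with a stated time of 48 h, tested at 1 uM; a lower number here means a stronger effect, a higher number a weaker effect of the compound at the concentration tested. Compound 1 `COc1ccc(-c2cc(/C=C/C(=O)c3cc(OC)c(OC)c(OC)c3)[nH]n2)cc1OC` gives 53% in this assay. Compound 2 `COc1ccc(C(=O)/C=C/c2cc(-c3cc(OC)c(OC)c(OC)c3)n[nH]2)cc1` gives 57%. Compound 3 `COc1ccc(C(=O)/C=C/c2cc(-c3cc(OC)c(OC)c(OC)c3)n[nH]2)cc1OC` gives 31%, the lowest of the three numbers and therefore the strongest effect; its gaps to compound 1, the nearest, and to compound 2, the furthest, both lie beyond the usual scatter.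

For the measured compounds named here, only one measured step changes a single place: a number 26 percentage points lower from compound 2 to compound 3 (beyond the scatter), methoxy in place of hydrogen on an aromatic carbon. Compound 4 `COc1cc(C(=O)/C=C/c2cc(-c3cc(OC)c(OC)c(OC)c3)n[nH]2)cc(OC)c1OC` differs from compound 3 by methoxy in place of hydrogen on an aromatic carbon, again methoxy in place of hydrogen on an aromatic carbon, though at another place on the same ring. Because the step of a number 26 percentage points lower from compound 2 to compound 3 (beyond the scatter) brought the number down, a further fall is expected, but a single step is thin evidence and the new place differs, so the expected step is a number 4 percentage points lower from compound 3 to compound 4 (within the scatter), modest at most. Compound 4 is estimated at 27%, within 10% to 48%.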

Compound 4, a percentage reported as activity, at one concentration (the size of the read-out at that concentration, not a potency): 40%
Compound 4: the middle estimate sits 13 percentage points below what was measured; the measured number falls inside the stated range.
By their numbers in this assay, from the lowest: compounds 3 and 4 (each within the scatter of the next); then compounds 1 and 2 (each within the scatter of the next).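

In this assay, a further methoxy on this ring does not extend the earlier gain: a number 9 percentage points higher from compound 3 to compound 4 (within the scatter). This place, ortho to a methoxy group and meta to a large group, therefore accepts the methoxy without a readable change in the number. On another core the same change does register: a number 13 percentage points lower from compound 1 to compound 4 (beyond the scatter). The two steps that lower the number agree in size, while the step from compound 3 to compound 4 stays within the scatter and goes against that pattern: the same change on two cores in this assay, a number 26 percentage points lower (beyond the scatter) from compound 2 to compound 3 and a number 13 percentage points lower (beyond the scatter) from compound 1 to compound 4, 13 percentage points apart, within the scatter of two such steps.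

It remains open whether this place responds to any group, since methoxy is the only one shown there, and an amine, a hydroxyl or a longer chain such as ethoxy might read differently. With one concentration in this assay, the results give the size of the effect and not a potency.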